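Notes on aryl replacement in the shared core series

A few compounds are considered here, and "the series" means these few. Any claim that something is new, unique, unknown or untested is made for them only; others in the source may bear on it.

Measured so far:
compound 1, `CCC1=C(O)c2c(oc(-c3ccc(COC)cc3)cc2=O)C(CC)(CC)C1=O`, 3.4 uM
compound 2, `CCC1=C(O)c2c(oc(-c3ccccc3OC)cc2=O)C(CC)(CC)C1=O`, 3.26 uM

In a functional assay on KBVIN cells (Homo sapiens) for antiproliferative activity, read by sulforhodamine B assay, with a stated time of 3 days (a higher number here means that more compound is needed for the effect, a lower number that less compound is needed), compound 1 gives 3.4 uM and compound 2 gives 3.26 uM. Compound 2 holds the lower of the two numbers, but the step of a 1.0-fold lower number from compound 1 to compound 2 (0.02 log units; within the scatter) places the pair within the scatter, so no order between them is claimed.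

Compound 3, `CCC1=C(O)c2c(oc(-c3ccc(OC)cc3C)cc2=O)C(CC)(CC)C1=O`, is not yet measured. It differs from compound 2 by 4-methoxy-2-methylphenyl in place of 2-methoxyphenyl on an aromatic carbon, on the carbon next to the ring oxygen of the shared core. For the measured compounds named here, the only step that bears on this change, a 1.0-fold lower number from compound 1 to compound 2 (0.02 log units; within the scatter), also exchanged one substituted phenyl for another on that same carbon and left the number within the scatter. On that basis no step beyond the scatter is expected for compound 3 in this assay, the expected step being a 1.0-fold higher number from compound 2 to compound 3 (0.01 log units; within the scatter). Compound 3 is therefore estimated at 3.3 uM, within a range of 1.5 uM to 7.5 uM.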

Compound 3, concentration for half-maximal effect: 2.62 uM
Compound 3: middle estimate off by 1.3-fold (0.10 log units), on the high side, and the stated range covers the measured number.
By their numbers in this assay, from the lowest: compounds 3, 2 and 1 (each within the scatter of the next).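

In this assay, 4-methoxy-2-methylphenyl is a third substituted phenyl on the aromatic carbon next to the ring oxygen of the shared core, and it gives a 1.2-fold lower number from compound 2 to compound 3 (0.09 log units; within the scatter) and also a 1.3-fold lower number from compound 1 to compound 3 (0.11 log units; within the scatter) with no step beyond the scatter. The three compounds therefore sit at one level in this assay, so the tolerated exchange now covers all three pairs, including a change of 8 to 9 heavy atoms between 2-methoxyphenyl and 4-methoxy-2-methylphenyl. Nothing at hand explains this flat result.

All three groups are phenyl rings bearing an ether oxygen and no net charge. On these data alone, whether an amine, a carboxylic acid or a pyridine ring on this carbon would hold that level remains open, as does the effect of an unsubstituted phenyl.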